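A few compounds are considered here, and "the series" means these few. Any claim that something is new, unique, unknown or untested is made for them only; others in the source may bear on it.

Working notes on the series. Three members of the shared core have so far been measured in an assay on isolated protein for inhibition of DNA topoisomerase 1 (Homo sapiens), with a stated time of 30 min, tested at 100 uM; on this read-out lower numbers stand for less inhibition and higher numbers for more inhibition at the one concentration tested (going by the name of the read-out). Compound 1 `Oc1ccc(-c2cc(-c3ccccc3O)cc(-c3cccc(O)c3)n2)cc1` gives 0% in this assay. Compound 2 `Oc1cccc(-c2cc(-c3cccc(O)c3)nc(-c3ccccc3O)c2)c1` gives 1.9% in this assay. Compound 3 `Oc1cccc(-c2cc(-c3ccccc3O)cc(-c3cccc(O)c3)n2)c1` gives 0% in this assay. Compound 3 thus stands level with compound 1, and the number for compound 2 sits within the scatter of both, so the three measured compounds cannot be told apart on this read-out.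

One step between measured compounds is of the kind now under consideration: no change at the digits printed from compound 1 to compound 3 (within the scatter). That change, one hydroxyphenyl isomer exchanged for another on the shared core, left the read-out where it was.

Compound 4 `Oc1cccc(-c2cc(-c3cccc(O)c3)nc(-c3cccc(O)c3)c2)c1` is the next member. It differs from compound 3 as follows: 3-hydroxyphenyl in place of 2-hydroxyphenyl on an aromatic carbon. Within the data shown here, the step from compound 1 to compound 3 is the only measured step that bears on this change, and it showed no movement beyond the scatter, so no movement beyond the scatter is expected here either, in neither direction, and the expected step is a number 1 percentage points higher from compound 3 to compound 4 (within the scatter). For compound 4 in this assay the estimate is therefore 1%, with a range from 0% to 8%.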

Compound 4, a percentage reported as inhibition, at one concentration (the size of the read-out at that concentration, not a potency): 0%
Compound 4: the middle estimate sits 1 percentage points above what was measured; measured number inside the range.
By their numbers in this assay, from the lowest: compounds 1, 3, 4 and 2 (each within the scatter of the next).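

With compound 4 the exchange of 2-hydroxyphenyl for 3-hydroxyphenyl has now been read directly, at the carbon opposite the ring nitrogen, and in this assay it gives no change at the digits printed from compound 3 to compound 4 (within the scatter) on that core. The same exchange at another place on the shared core gives a number 1.9 percentage points lower from compound 2 to compound 4 (within the scatter) and so stays within the scatter as well, which means that the 2-hydroxyphenyl group can be exchanged at either of these two places without a step beyond the scatter, and a compound carrying only 3-hydroxyphenyl groups reads no differently from its isomers. No measurement is at hand that would account for this flat result.

From the compounds shown here alone, all four compounds carry hydroxyphenyl groups only, so it remains open whether a methoxy group, an amine or a carboxylic acid in place of the hydroxyl would move the read-out on the shared core. No compound shown stands apart from the others at the one concentration tested, so these numbers give no potency and do not show which parts of the shared core, if any, the read-out responds to.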